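A few compounds are considered here, and "the series" means these few. Any claim that something is new, unique, unknown or untested is made for them only; others in the source may bear on it.

In an ADME assay on cells (Homo sapiens) for cytotoxicity, read by resazurin assay, with a stated time of 5 days (on this read-out higher numbers stand for lower toxicity in this test and lower numbers for higher toxicity in this test), three compounds sharing one core have been read so far. Compound 1 `O=S(=O)(Cc1nc(-c2ccncc2)c2sccc2n1)c1cccc(Cl)c1` gives > 50000 nM, which is a limit of the assay and not a number. Compound 2 `O=S(=O)(Cc1nc(-c2ccc(Cl)nc2)c2sccc2n1)c1cccc(Cl)c1` gives 70000 nM. Compound 3 `COc1ccc(-c2nc(CS(=O)(=O)c3cccc(Cl)c3)nc3ccsc23)cc1` gives 69000 nM. For the measured compounds named here, compound 3 therefore stands level with compound 2, the only other readable number, and the step between them is a 1.0-fold lower number from compound 2 to compound 3 (0.01 log units; within the scatter). The two steps that start from compound 1 give no size: a step that the limit leaves unreadable from compound 1 to compound 2 and a step that the limit leaves unreadable from compound 1 to compound 3.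

Compound 4 `O=S(=O)(Cc1nc(-c2ccoc2)c2sccc2n1)c1cccc(Cl)c1` carries furan-3-yl in place of 4-methoxyphenyl on an aromatic carbon, at the same place where the three measured compounds differ: furan-3-yl in place of 4-methoxyphenyl on an aromatic carbon. Going by the values given here, the only readable exchange at this place is the one from compound 2 to compound 3, a 1.0-fold lower number from compound 2 to compound 3 (0.01 log units; within the scatter), so it offers no ground for expecting a large move in this assay. Among the compounds with values here, no measured compound yet carries a five-membered ring here, which leaves the expectation resting on that single step. The expected change is a 1.1-fold lower number from compound 3 to compound 4 (0.05 log units; within the scatter), with no shift beyond the scatter foreseen in either direction. The estimated value for compound 4 is 62000 nM, with an expected range from 30000 nM to 110000 nM.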

Compound 4, half-maximal cytotoxic concentration: > 50000 nM
Compound 4: no number, only a limit (the forecaster's own chance of this, stated with the estimate: 35%); the middle value is on the limit's open side.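

In this assay compound 4 gives > 50000 nM, which is a limit of the assay and not a number. Its steps from compound 1, compound 2 and compound 3 therefore cannot be read: the limit of > 50000 nM in this assay, at which 2 of the 4 values shown sit. The compounds shown leave open what number compound 1 and compound 4 would give, and so how either compares with compound 2 or compound 3.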